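Aryl variation on the acrylamide of a quinazoline series

This account rests on a few compounds, and the source may have more. Where it says the series, first, only, none or still open, it means among the compounds named here.

Measured compounds in a functional assay on A549 cells (Homo sapiens) for cytotoxicity, read by MTT assay, with a stated time of 72 h; on this read-out higher numbers stand for weaker inhibition and lower numbers for stronger inhibition:
compound 1 `O=C(/C=C/c1cccc(Cl)c1Cl)Nc1cc2c(Nc3ccc(F)c(Cl)c3)ncnc2cc1O[C@H]1CCOC1`: 23200 nM
compound 2 `N#Cc1ccc(/C=C/C(=O)Nc2cc3c(Nc4ccc(F)c(Cl)c4)ncnc3cc2O[C@H]2CCOC2)cc1`: "not active" (no number reported)
compound 3 `COc1cc(/C=C/C(=O)Nc2cc3c(Nc4ccc(F)c(Cl)c4)ncnc3cc2O[C@H]2CCOC2)cc(OC)c1`: 10800 nM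

Compound 1 carries the highest of the two reported numbers; its nearest neighbour is compound 3, with a 2.1-fold lower number from compound 1 to compound 3 (0.33 log units; beyond the scatter), a modest step. Compound 2, bearing a nitrile on its aryl group, gave no number at all in this assay.

Compound 4 `COc1ccc(/C=C/C(=O)Nc2cc3c(Nc4ccc(F)c(Cl)c4)ncnc3cc2O[C@H]2CCOC2)cc1` is the next member to be read. It differs from compound 1 as follows: 4-methoxyphenyl in place of 2,3-dichlorophenyl on a double-bonded chain carbon bound to a double-bonded chain carbon

Among the compounds with values here, only one measured step bears on this change. Exchanging the 2,3-dichlorophenyl for a methoxy-bearing aryl gave a 2.1-fold lower number from compound 1 to compound 3 (0.33 log units; beyond the scatter), just beyond the scatter. Compound 2 warns that not every aryl exchange keeps activity, but it offers no number to scale against. The 4-methoxyphenyl of compound 4 is expected to behave roughly like compound 3, so a small downward step or none beyond the scatter is anticipated. The expected step is a 1.5-fold lower number from compound 1 to compound 4 (0.19 log units; within the scatter). Compound 4 is therefore estimated at 15000 nM, within a range from 6000 nM to 50000 nM.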

Compound 4, half-maximal inhibitory concentration: 3050 nM
Compound 4: middle estimate off by 4.9-fold (0.69 log units), on the high side, and the stated range ends above it.
By their numbers in this assay, from the lowest: compound 4; then compound 3; then compound 1.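

Within the data shown here, the aryl group on the double-bonded chain carbon has more influence on this read-out than the earlier compounds showed, with a 7.6-fold lower number from compound 1 to compound 4 (0.88 log units; beyond the scatter) against the smaller change seen for compound 3. Methoxy-bearing aryl groups are not interchangeable here: 4-methoxyphenyl in place of 3,5-dimethoxyphenyl still gives a 3.5-fold lower number from compound 3 to compound 4 (0.55 log units; beyond the scatter), which leaves compound 4 with the lowest number of the three in this assay. Nothing measured accounts for this order.

Among these compounds, compound 2 has no number, so no step involving it can be read, and the 4-methoxyphenyl result cannot be set against its nitrile on any scale. From the compounds shown here alone, it remains open whether an amine or a carboxylic acid in place of the methoxy of compound 4 would keep this number, and whether a plain phenyl would already reach it.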